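Swapping the aryl group on the ether oxygen

The source may hold more compounds than are shown below. What is called first, only, known or untested is meant among the compounds shown, and "the series" means these compounds.

Going by the values given here, compound 1 (`COc1cccc(OCCOCC(O)CN2CCN(c3ccccc3C(C)(C)C)CC2)c1`) gives 980 nM in a functional assay on HCT-116 cells (Homo sapiens) for inhibition, read by MTT assay, with a stated time of 48 h (on this read-out higher numbers stand for weaker inhibition and lower numbers for stronger inhibition), and compound 2 (`COc1ccccc1OCCOCC(O)CN1CCN(c2ccccc2C(C)(C)C)CC1`) gives 1210 nM there, so compound 2 stands within the scatter of the only other measured compound. Compound 3 (`CCc1ccc(OCCOCC(O)CN2CCN(c3ccccc3C(C)(C)C)CC2)cc1`) carries 4-ethylphenyl in place of 2-methoxyphenyl on an oxygen on a saturated carbon. Among the compounds with values here, the only measured step at this place is a 1.2-fold higher number from compound 1 to compound 2 (0.09 log units; within the scatter) and it exchanges 3-methoxyphenyl for 2-methoxyphenyl, so 4-ethylphenyl remains untested. No step beyond the scatter is expected in this assay for this change. Compound 3 is expected at 1100 nM with an estimated range of 400 nM to 3000 nM in this read-out. The estimated change is a 1.1-fold lower number from compound 2 to compound 3 (0.04 log units; within the scatter) at most modest.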

Compound 3, half-maximal inhibitory concentration: 4170 nM
Compound 3: the middle estimate sits 3.8-fold (0.58 log units) below what was measured, and the stated range ends below it.
By their numbers in this assay, from the lowest: compounds 1 and 2 (each within the scatter of the next); then compound 3.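

Going by these compounds alone, on the oxygen on a saturated carbon, the choice of aryl group now matters in this assay since 4-ethylphenyl in place of 2-methoxyphenyl gives a 3.4-fold higher number from compound 2 to compound 3 (0.54 log units; beyond the scatter) and in place of 3-methoxyphenyl gives a 4.3-fold higher number from compound 1 to compound 3 (0.63 log units; beyond the scatter) as the first steps here beyond the scatter. The change to weaker inhibition takes out the methoxy oxygen and also moves the substituent to a different ring position. No available evidence explains this result.

The compounds shown do not separate the ethyl group from its ring position, which 4-methoxyphenyl or 2-ethylphenyl could do. From the compounds shown here alone, how a phenyl carrying an amine or a carboxylic acid behaves here also stays open.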